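Biphenyl amide series: tert-butyl replaced by (methylamino)methyl

The source may hold more compounds than are shown below. What is called first, only, known or untested is meant among the compounds shown, and "the series" means these compounds.

Of the compounds shown here, two have been measured. Compound 1 `CC[C@H](C)[C@H](N)CN(C(=O)[C@@H]1C[C@H]1c1ccc(F)cc1)c1ccc(-c2ccccc2)cc1` carries a fluorine on the phenyl of the cyclopropane and an unsubstituted biphenyl; in a functional assay for agonist activity at G protein-coupled receptor 88 (Homo sapiens), read by HTRF and cAMP accumulation (on this read-out higher numbers stand for an effect only at larger amounts of compound and lower numbers for an effect already at smaller amounts), compound 1 gives 600 nM. Compound 2 `CC[C@H](C)[C@H](N)CN(C(=O)[C@@H]1C[C@H]1c1ccccc1)c1ccc(-c2ccc(C(C)(C)C)cc2)cc1` carries an unsubstituted phenyl on the cyclopropane and a tert-butyl group on the distal ring of the biphenyl; in this assay compound 2 gives 750 nM. The two values lie within the scatter of each other, so neither compound can be set apart from the other on these numbers; compound 2 simply stands at the same level as compound 1.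

Compound 3 `CC[C@H](C)[C@H](N)CN(C(=O)[C@@H]1C[C@H]1c1ccccc1)c1ccc(-c2ccc(CNC)cc2)cc1` has not been measured. It differs from compound 2 in one place: (methylamino)methyl in place of tert-butyl on an aromatic carbon. Within the data shown here, no measured pair shows a step of this kind, so there is nothing to size the change. The expectation is therefore a step from compound 2 to compound 3 in this assay of a 1.2-fold higher number from compound 2 to compound 3 (0.08 log units; within the scatter), at most a small shift toward higher numbers and possibly none beyond the scatter. Compound 3 is estimated at 900 nM, with a range from 300 nM to 2700 nM.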

Compound 3, half-maximal effective concentration: 6400 nM
For compound 3 the middle estimate is 7.1-fold (0.85 log units) below the measured one; measured number above the stated range.
By their numbers in this assay, from the lowest: compounds 1 and 2 (each within the scatter of the next); then compound 3.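

In this assay, the aromatic carbon para to a large group turns out not to be indifferent to its substituent: (methylamino)methyl in place of tert-butyl gives an 8.5-fold higher number from compound 2 to compound 3 (0.93 log units; beyond the scatter), a step beyond the scatter, whereas compound 1 and compound 2 differ in two places and gave no reading of this position alone. The change exchanges a group of carbon only, with no hydrogen-bond donor or acceptor, for a smaller one holding a nitrogen, with one hydrogen-bond donor and one hydrogen-bond acceptor, and this single step does not separate which of these differences goes with the higher number. No measurement at hand ties the step to any property of either group.

Open, going by these compounds, is whether the step follows from the nitrogen or from the loss of tert-butyl; a plain hydrogen, an isopropyl, an aminomethyl, a dimethylaminomethyl or a methoxymethyl on the same carbon would help to tell these apart. Also open, on these data alone, is whether a step of this size persists with fluorine on the phenyl of the cyclopropane, the feature carried by compound 1.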